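This account rests on a few compounds, and the source may have more. Where it says the series, first, only, none or still open, it means among the compounds named here.

Measured so far in an ADME assay on the whole organism (strain Han-Wistar) for pharmacokinetics, with Rattus norvegicus as the target, read by LC-MS, at a dose of 2 mg/kg by the oral route; on this read-out lower numbers stand for lower exposure and higher numbers for higher exposure at the dose given:

Compound 1 `CN1CCN(CCCS(=O)(=O)c2ccc3nc(NC(=O)NC(=O)c4cc(-n5cccc5)ccc4Cl)sc3c2)CC1` gives 580 nM.
Compound 2 `CCc1ccc(Cl)c(C(=O)NC(=O)Nc2nc3ccc(S(=O)(=O)CCCN4CCN(C)CC4)cc3s2)c1` gives 1500 nM.
Compound 3 `CN1CCN(CCCS(=O)(=O)c2ccc3nc(NC(=O)NC(=O)c4cc5c(ccn5C)cc4Cl)sc3c2)CC1` gives 300 nM.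

Compound 1 stands second highest of the three numbers: compound 3 lies within the scatter of it, while compound 2 lies beyond it, as the step of a 2.6-fold higher number from compound 1 to compound 2 (0.41 log units; beyond the scatter) shows. Compound 4 `CN1CCN(CCCS(=O)(=O)c2ccc3nc(NC(=O)NC(=O)c4cc(N5CCCC5)ccc4Cl)sc3c2)CC1` differs from compound 1 only by pyrrolidin-1-yl in place of 1H-pyrrol-1-yl on an aromatic carbon. Of the measured steps, a 2.6-fold higher number from compound 1 to compound 2 (0.41 log units; beyond the scatter) bears most directly on this, since it also replaces the 1H-pyrrol-1-yl group at the same aromatic carbon and gave a modest rise; a 1.9-fold lower number from compound 1 to compound 3 (0.29 log units; within the scatter) was within the scatter. Compound 4 is therefore expected to move little from compound 1, with a step of about a 1.3-fold higher number from compound 1 to compound 4 (0.11 log units; within the scatter), leaning upward. The estimate for compound 4 in this assay is 750 nM, within 300 nM to 1800 nM.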

Compound 4, maximal plasma concentration: 640 nM
Beside the measured number, compound 4's estimate is 1.2-fold (0.07 log units) above it; the range from low to high includes it.
By their numbers in this assay, from the lowest: compounds 3, 1 and 4 (each within the scatter of the next, the first and the last beyond it); then compound 2.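

In this assay, a non-aromatic ring of the same size on this aromatic carbon, para to the chloro group, leaves the read-out in place of the aromatic one, with a 1.1-fold higher number from compound 1 to compound 4 (0.04 log units; within the scatter). The pyrrolidin-1-yl group still falls short of ethyl at this carbon, with a 2.3-fold lower number from compound 2 to compound 4 (0.37 log units; beyond the scatter), and the 2-chloro-5-(pyrrolidin-1-yl)phenyl group stands clear of the 5-chloro-1-methyl-1H-indol-6-yl group, with a 2.1-fold higher number from compound 3 to compound 4 (0.33 log units; beyond the scatter). Nothing measured here gives a reason for these steps.

The compounds shown leave open whether a morpholine ring, a methoxy group or a propyl chain on this carbon would read with the two ring compounds or with ethyl.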